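A few compounds are considered here, and "the series" means these few. Any claim that something is new, unique, unknown or untested is made for them only; others in the source may bear on it.

Measured in a functional assay on ileum (strain Hartley) for agonist activity at 5-hydroxytryptamine receptor 3A (Cavia porcellus); on this read-out lower numbers stand for lower potency and higher numbers for higher potency (the scale is a negative logarithm):
- compound 1 `CN1CCN(c2nc3cc([N+](=O)[O-])ccc3o2)CC1`: 6.1
- compound 2 `COc1ccc2oc(N3CCN(C)CC3)nc2c1`: 4.78
- compound 3 `CN1CCN(c2nc3cc(F)ccc3o2)CC1`: 5.57

Compound 3 holds the middle place of these three. Its nearest neighbour is compound 1, and the step of a number 0.53 log units lower from compound 1 to compound 3 (beyond the scatter) lies beyond the scatter; its furthest neighbour is compound 2, and the step of a number 0.79 log units higher from compound 2 to compound 3 (beyond the scatter) also lies beyond the scatter. The widest gap at this position is a number 1.32 log units lower from compound 1 to compound 2 (beyond the scatter).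

Compound 4 `CCc1ccc2oc(N3CCN(C)CC3)nc2c1` is not yet measured. Compared with compound 3 it carries ethyl in place of fluoro on an aromatic carbon. For the measured compounds named here, no measured step brings an ethyl group in at this position, so the three known steps show only that swapping the group there moves the read-out by modest to large amounts. An ethyl group is not among the groups tried so far, and the expectation therefore rests on that spread alone. Compound 4 is expected to give 5.3, with a range from 4.6 to 6. The step from compound 3 to compound 4 is thus estimated as a number 0.27 log units lower from compound 3 to compound 4 (within the scatter).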

Compound 4, negative logarithm of the half-maximal effective concentration: < 4
Compound 4 gave a limit, no number; the forecaster's own chance of this, stated with the estimate: 5%; at least 1.30 log units between middle value and limit.
By their numbers in this assay, from the lowest: compound 2; then compound 3; then compound 1. At a limit, below all of these: compound 4.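

In this assay compound 4 reaches only a limit, not a number: the limit of < 4 in this assay, at which 1 of the 4 values shown sits.
Even so, the steps of a number at least 1.57 log units lower from compound 3 to compound 4 (beyond the scatter) and a number at least 0.78 log units lower from compound 2 to compound 4 (beyond the scatter) and a number at least 2.10 log units lower from compound 1 to compound 4 (beyond the scatter) place ethyl under every group seen so far at this position, so methoxy no longer marks the low end of the range. Fluoro and ethyl both count no hydrogen-bond donors or acceptors, yet the step between them is large, so those counts alone cannot separate the groups here.

From the compounds shown here alone, how far under the limit compound 4 really lies stays unknown, so these steps have only a lower bound. Going by these compounds, whether a methyl group, a longer chain or an amine at this position would fall as ethyl does, or hold up as nitro does in compound 1, also stays open.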